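A pyridine swap at the carbonyl of compound 1

This account rests on a few compounds, and the source may have more. Where it says the series, first, only, none or still open, it means among the compounds named here.

Compound 1 `COC(=O)c1scc(-c2ccc(NC(=O)c3ccc(F)c(Cl)n3)cc2)c1OC`: 10300 nM
Compound 2 `COC(=O)c1scc(-c2ccc(NC(=O)c3ccc(C(F)(F)F)cc3Br)cc2)c1OC`: 28200 nM
Compound 3 `COC(=O)c1scc(-c2ccc(NC(=O)c3cccc(OC(F)(F)F)c3)cc2)c1OC`: 720 nM

These values come from a functional assay on HepG2 cells (Homo sapiens) for antiproliferative activity, read by MTT assay, with a stated time of 24 h; a lower number here means a stronger inhibitor, a higher number a weaker inhibitor. Compound 1 stands second highest of the three numbers. The gaps from compound 1 to the other two compounds both lie beyond the usual scatter.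

Compound 4 `COC(=O)c1scc(-c2ccc(NC(=O)c3ccc(OC)nc3)cc2)c1OC` has not yet been measured. It keeps the core of compound 1 but carries 6-methoxypyridin-3-yl in place of 6-chloro-5-fluoropyridin-2-yl on a carbonyl carbon.

Among the measured compounds shown here, no measured pair isolates such a swap, so the guide is loose. Compound 3, at 720 nM, shows that much lower numbers occur with this core. In this assay a moderate move toward a lower number is expected, a 2.1-fold lower number from compound 1 to compound 4 (0.31 log units; beyond the scatter). For compound 4 the estimate is 5000 nM, with an expected range of 1000 nM to 22000 nM.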

Compound 4, half-maximal inhibitory concentration: > 50000 nM
Compound 4: a limit, no number; the forecaster's own chance of this, stated with the estimate: 3%; middle value at least 10-fold (1.00 log units) away from the limit.
By their numbers in this assay, from the lowest: compound 3; then compound 1; then compound 2. At a limit, above all of these: compound 4.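

In this assay, among the compounds shown here, the swap to 6-methoxypyridin-3-yl on a carbonyl carbon gives an at least 4.8-fold higher number from compound 1 to compound 4 (0.68 log units; beyond the scatter), the first step here that isolates a change at this place. A pyridine at this place therefore does not secure activity by itself, since these two pyridines are far from interchangeable. The value for compound 4 is a limit, so the full size of the step stays unknown: the limit of > 50000 nM in this assay, at which 1 of the 4 values shown sits.

On these data alone, whether the loss follows the methoxy group or the pyridine attachment remains open. So does how an amine or a nitrile on the pyridine would read.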